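This account rests on a few compounds, and the source may have more. Where it says the series, first, only, none or still open, it means among the compounds named here.

Of the compounds shown here, two with a shared core have been measured in an ADME assay on Caco-2 cells (Homo sapiens) for permeability, read by LC-MS, with a stated time of 2 h; a lower number here means that the compound crosses the layer more slowly, a higher number that the compound crosses the layer faster. Compound 2 (`COc1cc(CN(CC(C)C)C(CC(=O)O)c2ccc(Cl)cc2)ccc1OCCN1C(=O)CCC1=O`) gives 3 nm/s, and compound 1 (`CCCCN(Cc1ccc(OCCn2c(=O)ccn(C)c2=O)c(OC)c1)C(CC(=O)O)c1ccc(Cl)cc1`) gives 1.5 nm/s. These two values lie within the usual scatter of each other, so compound 2 cannot be ranked apart from compound 1, and both belong to one small group of readings.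

The next compound to be tested is compound 3 (`COc1cc(CN(CC(C)C)C(CC(=O)O)c2ccc(Cl)cc2Cl)ccc1OCCN1C(=O)CCC1=O`). It is built from compound 2 by a single change, chloro in place of hydrogen on an aromatic carbon, which turns the 4-chlorophenyl into a 2,4-dichlorophenyl. Among the measured compounds shown here, no measured pair shows what a change made in one place does in this assay, so the data give no direct precedent for this step.

The expectation therefore starts from compound 2 at 3 nm/s and allows for no shift beyond the scatter. The expected result is a 1.2-fold higher number from compound 2 to compound 3 (0.07 log units; within the scatter), a small estimated step upward at most. In this assay, compound 3 is estimated at 3.5 nm/s, with an expected range of 1.5 nm/s to 8 nm/s.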

Compound 3, apparent permeability: 28.1 nm/s
For compound 3 the middle estimate is 8.0-fold (0.90 log units) below the measured one; measured number outside the range, above it.
By their numbers in this assay, from the lowest: compounds 1 and 2 (each within the scatter of the next); then compound 3.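

In this assay, chloro in place of hydrogen on this aromatic carbon, ortho to a large group and meta to a chloro group, gives a 9.4-fold higher number from compound 2 to compound 3 (0.97 log units; beyond the scatter) and so stands beyond the usual scatter. Among the compounds shown here, this is the first change made in one place, and it shows that the position can move the reading even though the change adds only one chlorine atom, with no hydrogen-bond donor or acceptor and no net charge. No measurement at hand gives a property that would account for the size of this step.

The compounds shown do not tell whether the chloro group itself matters at this position or whether another group there, such as fluoro, methyl or methoxy, would give a step of similar size. They also leave open whether the 2,4-dichlorophenyl gives the same kind of step on the core of compound 1, and whether a chloro group at this place would do so without the chloro group already present in the 4-chlorophenyl.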